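Furan to methoxyphenyl swap on the cyanoacrylamide series

The source may hold more compounds than are shown below. What is called first, only, known or untested is meant among the compounds shown, and "the series" means these compounds.

Compound 1 `N#C/C(=C\c1ccco1)C(=O)NCc1ccc(Cl)c(Cl)c1` stands at the edge of what a functional assay on BE(2)-C cells (Homo sapiens) for inhibition, read by MTT assay, with a stated time of 72 h (on this read-out lower numbers stand for stronger inhibition of growth and higher numbers for weaker inhibition of growth), can report: compound 1 gives > 50000 nM, which is a limit of the assay rather than a number (the limit of > 50000 nM in this assay, at which 1 of the 3 values shown sits). Compound 2 `COc1ccc(CNC(=O)/C(C#N)=C/c2ccc(C)o2)cc1` gives 21000 nM in this assay, and compound 3 `COc1ccc(CNC(=O)/C(C#N)=C/c2ccc(C)cc2)cc1` gives 35000 nM. The change to compound 4 `COc1ccc(/C=C(\C#N)C(=O)NCc2ccc(Cl)c(Cl)c2)cc1` is 4-methoxyphenyl in place of furan-2-yl on a double-bonded chain carbon bound to a double-bonded chain carbon. Among the measured compounds shown here, the only measured step that bears on it is a 1.7-fold higher number from compound 2 to compound 3 (0.22 log units; within the scatter), an aryl-for-furan exchange at the same place that stayed within the scatter. For the measured compounds named here, compound 1 itself offers no measured step, standing only at a limit. Compound 4 is therefore expected to show no step beyond the scatter, that is a number no higher from compound 1 to compound 4 (the limit leaves the size open), and is estimated at 50000 nM, in the range 15000 nM to 150000 nM.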

Compound 4, concentration for 50% growth inhibition: 93000 nM
Beside the measured number, compound 4's estimate is 1.9-fold (0.27 log units) below it; measured number inside the range.
By their numbers in this assay, from the lowest: compounds 2 and 3 (each within the scatter of the next); then compound 4.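

No step can be read from compound 1 to compound 4, since the value of compound 1 is a limit and not a number: the limit of > 50000 nM in this assay, at which 1 of the 4 values shown sits.

The compounds shown leave open how far 4-methoxyphenyl in place of furan-2-yl shifts the number in this assay.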